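Amino for hydroxy on a quiet benzylamine

The source may report more compounds than this note shows. Statements on the series, on what has been measured and on what is new or still open speak of the compounds shown alone.

Three compounds share a core and differ only in the groups on their outer aromatic ring. Compound 1 `Oc1cccc(CNc2cc(Br)cc3[nH]ncc23)c1` carries a single hydroxy group, and in an assay for inhibition of Tryptophan 2,3-dioxygenase (Homo sapiens), with a stated time of 1 h, tested at 10 uM (a lower number here means less inhibition, a higher number more inhibition at the concentration tested (going by the name of the read-out)), compound 1 gives 55%. Compound 2 `Nc1cccc(CNc2cc(Br)cc3[nH]ncc23)c1` carries a single amino group instead, and in this assay compound 2 is reported as "not active" (no number reported). Compound 3 `Oc1ccc(CNc2cc(Br)cc3[nH]ncc23)cc1O` carries two hydroxy groups, and in this assay compound 3 is likewise reported as "not active" (no number reported); no number stands against it, so compound 3 is placed only as one of two compounds without a figure, alongside compound 2.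

Compound 4 `Nc1cc(CNc2cc(Br)cc3[nH]ncc23)ccc1O` is not yet measured. It differs from compound 3 in one place: amino in place of hydroxy on an aromatic carbon. Among the compounds with values here, no step between measured compounds describes this exchange. Within the data shown here, compound 2, the only measured compound bearing an amino group, is reported as "not active" (no number reported), which argues against a gain beyond the scatter. Compound 4 is therefore expected to give about 10%, with a range from 0% to 35%, and a fair chance that only inactivity is reported.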

Compound 4, a percentage reported as inhibition, at one concentration (the size of the read-out at that concentration, not a potency): "not active" (no number reported)
Nothing numeric was reported for compound 4; no gap can be computed for the estimate.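

In this assay compound 3 gives "not active" (no number reported) and compound 4 gives "not active" (no number reported) and so no step can be read between them; nothing at hand bears on this result.

The compounds shown leave open what amino in place of hydroxy does to inhibition where a number can be reported.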